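A few compounds are considered here, and "the series" means these few. Any claim that something is new, unique, unknown or untested is made for them only; others in the source may bear on it.

In an ADME assay on liver for metabolic stability, with Liver microsome (Rattus norvegicus) as the target, read by LC-MS, using microsomes, with a stated time of 5 h (a lower number here means slower removal, a higher number faster removal of the compound), compound 2 `O[C@H](c1ccccn1)[C@]1(c2cccc(OC(F)(F)F)c2)C[C@H](O)C1` gives 117 mL/min/kg. Compound 1 `O[C@H](c1ccccn1)[C@]1(c2cccc(OC(F)(F)F)c2)C[C@@H](O)C1` gives 217 mL/min/kg, and compound 3 `O[C@H](c1ccccn1)[C@]1(c2cccc(C(F)(F)F)c2)C[C@H](O)C1` gives 183 mL/min/kg. Compound 2 therefore stands within the scatter of both of these compounds. Compound 4 `O[C@H](c1ccccn1)C1(c2cccc(OC(F)(F)F)c2)CCC1` departs from compound 2 by a single change: hydrogen in place of hydroxy on a saturated ring carbon.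

For the measured compounds named here, two measured steps bear on this change, and neither removes the group. The nearer one touches the same ring carbon: there is a 1.9-fold lower number from compound 1 to compound 2 (0.27 log units; within the scatter), and it goes with the fact that compounds 1 and 2 differ only in the configuration as drawn. The other lies on the aromatic side of the molecule: there is a 1.6-fold higher number from compound 2 to compound 3 (0.19 log units; within the scatter), with trifluoromethyl in place of trifluoromethoxy on an aromatic carbon. Going by the values given here, the data contain no direct measure of losing the hydroxy, so the size of these two steps is the only guide. In this assay, a step of similar size is therefore expected, leaning slightly towards faster removal but not clearly beyond the scatter. The expected move is a 1.5-fold higher number from compound 2 to compound 4 (0.16 log units; within the scatter). For compound 4 the estimated clearance is 170 mL/min/kg, with an expected range from 90 mL/min/kg to 320 mL/min/kg.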

Compound 4, clearance: 1720 mL/min/kg
Beside the measured number, compound 4's estimate is 10-fold (1.01 log units) below it, and the stated range ends below it.
By their numbers in this assay, from the lowest: compounds 2, 3 and 1 (each within the scatter of the next); then compound 4.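

In this assay, the hydroxy on this saturated ring carbon of the four-membered ring proves to count for far more than its drawn configuration: replacing it with hydrogen gives a 15-fold higher number from compound 2 to compound 4 (1.17 log units; beyond the scatter), and the same change read from the other configuration gives a 7.9-fold higher number from compound 1 to compound 4 (0.90 log units; beyond the scatter). For the compounds shown here, both steps lie beyond the scatter, so the change moves the number from either starting configuration, whereas the earlier steps, one at this ring carbon and one on the aromatic ring, stayed within it. Presence or absence of the hydroxy thus separates these compounds, while the two hydroxy compounds stand within the scatter of each other, and the only difference between them is this: the fact that compounds 1 and 2 differ only in the configuration as drawn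

The compounds shown leave open whether any other group at this ring carbon, such as a methoxy group, an amine or a fluorine atom, would hold the number near that of compound 2 or let it move towards that of compound 4. They also leave open whether removing the hydroxy would give a step of similar size with the trifluoromethyl group of compound 3 on the aromatic ring.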